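Pyridone for fluoropyridine on a shared sulfone core

The source may hold more compounds than are shown below. What is called first, only, known or untested is meant among the compounds shown, and "the series" means these compounds.

Compound 3 `CCCCc1[nH]c(=O)c(S(=O)(=O)c2ccc(-c3ccc(F)nc3)cc2)c(O)c1-c1c(OC)cccc1OC` gives "not determined" (no result reported) in an ADME assay on microsomes from liver (Mus musculus) for metabolic stability, using NADPH, with a stated time of 10 min; a higher number here means that more of the compound is left, a lower number that less of the compound is left; no result was obtained for it. Its neighbours on the same core give a footing: compound 1 `CCCCc1[nH]c(=O)c(S(=O)(=O)c2ccc(-c3ccncc3C)cc2)c(O)c1-c1c(OC)cccc1OC` shows 39% in this assay, and compound 2 `CCCCc1[nH]c(=O)c(S(=O)(=O)c2ccc(-c3cccnc3OC)cc2)c(O)c1-c1c(OC)cccc1OC` shows 24%. Among the measured compounds shown here, the only step between measured compounds, a number 15 percentage points lower from compound 1 to compound 2 (beyond the scatter), is a modest fall on swapping one six-membered ring for another. Compound 4 `CCCCc1[nH]c(=O)c(S(=O)(=O)c2ccc(-n3ccccc3=O)cc2)c(O)c1-c1c(OC)cccc1OC` differs from compound 3 by a group of 7 heavy atoms (5 carbon, 1 nitrogen, 1 oxygen; one six-membered aromatic ring with 1 hetero atom) in place of a group of 7 heavy atoms (5 carbon, 1 nitrogen, 1 fluorine; one six-membered aromatic ring with 1 hetero atom), on an aromatic carbon. For the measured compounds named here, no measured step bears directly on this exchange, so only a shift of modest size in either direction, or none beyond the scatter, can be expected. For compound 4 the percent remaining is estimated at 30%, within a range of 10% to 55%.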

Compound 4, percent of the compound remaining: 75%
Compound 4: middle estimate off by 45 percentage points, on the low side; the whole stated range lies below it.
By their numbers in this assay, from the lowest: compound 2; then compound 1; then compound 4.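

In this assay, the place para to a large group proves far more responsive than the earlier pair showed: there is a number 51 percentage points higher from compound 2 to compound 4 (beyond the scatter) and a number 36 percentage points higher from compound 1 to compound 4 (beyond the scatter) and both steps are large. The entering group of compound 4 keeps a six-membered aromatic ring with one hetero atom, as the groups of compound 1 and compound 2 do, but adds one double bond outside that ring. Nothing available here accounts for this rise.

The step from compound 3 cannot be read, as compound 3 has no number. From the compounds shown here alone, how an amine or a carboxylic acid on that ring would fare in this assay remains open.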